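Swapping the fluoropyridine for a methylpyrazole on compound 1

The source may report more compounds than this note shows. Statements on the series, on what has been measured and on what is new or still open speak of the compounds shown alone.

Measured compounds:
compound 1, `COc1ccc(CNC(=O)c2cc(-c3cncc(C)c3)ncc2-c2cncc(F)c2)nc1OC`: 17000 nM
compound 2, `COc1ccc(CNC(=O)c2sc(-c3cncc(C)c3)nc2-c2cccc(F)c2)nc1OC`: 12000 nM
compound 3, `COc1ccc(CNC(=O)c2nc(-c3cncc(C)c3)cnc2-c2ccccc2)nc1OC`: 8500 nM

In an assay on CHO cells for displacement of a labelled ligand from Orexin/Hypocretin receptor type 1 variant I408V (Homo sapiens), read by scintillation counting (a higher number here means a weaker inhibitor, a lower number a stronger inhibitor), compound 1 gives 17000 nM. Compound 2 and compound 3 sit close by, and all three values fall within the usual scatter of one another, so none of them can be set apart from the rest. Compound 4, `COc1ccc(CNC(=O)c2cc(-c3cncc(C)c3)ncc2-c2cnn(C)c2)nc1OC`, has not been measured. It differs from compound 1 by 1-methyl-1H-pyrazol-4-yl in place of 5-fluoropyridin-3-yl on an aromatic carbon. Among the compounds with values here, no measured pair shows a change of this kind, so there is no step to lean on. With the three known values so tightly grouped, the expectation is that the step of a 1.1-fold lower number from compound 1 to compound 4 (0.05 log units; within the scatter) stays within the scatter. Compound 4 is therefore estimated at 15000 nM, ranging from 5000 nM to 45000 nM.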

Compound 4, inhibition constant: 930 nM
Estimate against measurement, compound 4: 16-fold (1.21 log units) above, outside the stated range (below it).
By their numbers in this assay, from the lowest: compound 4; then compounds 3, 2 and 1 (each within the scatter of the next).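

In this assay, the place on the six-membered aromatic ring with 1 nitrogen, ortho to a large group, proves sensitive to what it carries: 1-methyl-1H-pyrazol-4-yl in place of 5-fluoropyridin-3-yl gives an 18-fold lower number from compound 1 to compound 4 (1.26 log units; beyond the scatter) and sets compound 4 apart from the rest. The three earlier compounds, all within the scatter of one another, showed no such separation. No available evidence accounts for this step.

Going by these compounds, whether the methyl on the pyrazole matters remains open, as does whether an ethyl group or an amine there would hold the gain. Also open, on these data alone, is whether the same swap carries over to the cores of compound 2 and compound 3.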